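A few compounds are considered here, and "the series" means these few. Any claim that something is new, unique, unknown or untested is made for them only; others in the source may bear on it.

Measured compounds:
- compound 1, `COc1ccc(-c2cn(CC(=O)Nc3nc4ccccc4s3)nn2)cc1`: 1330 nM
- compound 2, `Cc1cc(NC(=O)Cn2cc(-c3ccc(F)cc3)nn2)no1`: > 30000 nM
- compound 3, `CCOC(=O)c1sc(NC(=O)Cn2cc(-c3ccc([N+](=O)[O-])cc3)nn2)nc1C`: 1840 nM

In a functional assay on BMDM cells (Mus musculus, strain C57BL/6) for inhibition, with a stated time of 2 days (on this read-out higher numbers stand for weaker inhibition and lower numbers for stronger inhibition), compound 1 gives 1330 nM, the lower of the two numbers, while compound 3 sits within the usual scatter of it. For compound 2 this assay reports only a limit, (the limit of > 30000 nM in this assay, at which 1 of the 3 values shown sits). The unmeasured compound 4, `N#Cc1ccc(-c2cn(CC(=O)Nc3nc4ccccc4s3)nn2)cc1`, differs from compound 1 by cyano in place of methoxy on an aromatic carbon. Going by the values given here, no step between measured compounds shows what such a swap does, so no change beyond the scatter is anticipated in this assay. Compound 4 is therefore expected to give 1500 nM, between 400 nM and 6000 nM, which corresponds to an estimated step of a 1.1-fold higher number from compound 1 to compound 4 (0.05 log units; within the scatter).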

Compound 4, half-maximal inhibitory concentration: > 30000 nM
Compound 4: no number, only a limit; the forecaster's own chance of this, stated with the estimate: 10%; middle value at least 20-fold (1.30 log units) from the limit.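

In this assay, the methoxy position on the aromatic ring, para to a large group, proves sensitive: cyano in place of methoxy gives an at least 22-fold higher number from compound 1 to compound 4 (1.35 log units; beyond the scatter), although the two groups match in heavy atoms and hydrogen-bond acceptors. The entry for compound 4 is only a limit of the assay, so the step has a lower bound and no exact size: the limit of > 30000 nM in this assay, at which 2 of the 4 values shown sit.

The compounds shown leave open whether this loss belongs to cyano alone or extends to other replacements such as an amine, a chlorine or an ethoxy group. They also leave open whether the same swap acts alike on a different core.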